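Dimethoxy Hydrazone Follows the Highest-Scoring Methoxy Analogue

A few compounds are considered here, and "the series" means these few. Any claim that something is new, unique, unknown or untested is made for them only; others in the source may bear on it.

Compound 3 `COc1cccc(/C=N/NC(=O)c2cccnc2Nc2cccc(C(F)(F)F)c2)c1` gives 58.8% in a functional assay on the whole organism (strain Wistar) for inhibition, with Rattus norvegicus as the target, read by paw edema, with a stated time of 1 h, at a dose of 10 mg/kg by the intraperitoneal route; on this read-out higher numbers stand for more inhibition at the one dose given (going by the name of the read-out) and lower numbers for less inhibition. That is the highest of the three numbers measured, though both others lie within the scatter of it: compound 1 `O=C(N/N=C/c1ccccc1)c1cccnc1Nc1cccc(C(F)(F)F)c1` gives 53.9%, and compound 2 `O=C(N/N=C/c1cccc(F)c1)c1cccnc1Nc1cccc(C(F)(F)F)c1` gives 51.5%. The unmeasured candidate is compound 4 `COc1ccc(/C=N/NC(=O)c2cccnc2Nc2cccc(C(F)(F)F)c2)c(OC)c1`. Its change from compound 3 is 2,4-dimethoxyphenyl in place of 3-methoxyphenyl on a carbon with a double bond to nitrogen. Earlier steps on the same ring bear on it: a number 4.9 percentage points higher from compound 1 to compound 3 (within the scatter), a number 7.3 percentage points higher from compound 2 to compound 3 (within the scatter) and a number 2.4 percentage points lower from compound 1 to compound 2 (within the scatter); none of them left the scatter. The account therefore expects a step of a number 1.8 percentage points lower from compound 3 to compound 4 (within the scatter) in this assay, no direction beyond the scatter. Compound 4 is estimated at 57%, within 45% to 69%.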

Compound 4, a percentage reported as inhibition, in the whole organism at one dose (the size of the read-out at that dose, not a potency): 55.7%
Estimate against measurement, compound 4: 1.3 percentage points above; measured number inside the range.
By their numbers in this assay, from the lowest: compounds 2, 1, 4 and 3 (each within the scatter of the next).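

The 2,4-dimethoxyphenyl group on the carbon with a double bond to nitrogen gives a number 3.1 percentage points lower from compound 3 to compound 4 (within the scatter) and a number 4.2 percentage points higher from compound 2 to compound 4 (within the scatter) and a number 1.8 percentage points higher from compound 1 to compound 4 (within the scatter) in this assay. The position therefore takes a ring with two methoxy groups as well as one with a single methoxy, and no step among these four compounds leaves the scatter. Nothing measured here accounts for these steps. Still open, as far as these compounds go, is whether a ring carrying an amine or a carboxylic acid would give a step beyond the scatter in this assay.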